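A few compounds are considered here, and "the series" means these few. Any claim that something is new, unique, unknown or untested is made for them only; others in the source may bear on it.

Measured so far in an ADME assay on MT4 cells (Homo sapiens) for cytotoxicity, read by MTT assay, with a stated time of 4 days; a higher number here means that more compound is tolerated, a lower number that less compound is tolerated:
- compound 1 `Cc1cc(C)cc(Cn2c(=O)cc(NC3CC3)n(Cc3ccccc3)c2=O)c1`: > 100000 nM
- compound 2 `Cc1cc(C)cc(Cn2c(=O)cc(N=[N+]=[N-])n(Cc3ccccn3)c2=O)c1`: > 100000 nM

Compound 1 `Cc1cc(C)cc(Cn2c(=O)cc(NC3CC3)n(Cc3ccccc3)c2=O)c1` is where the series is anchored. In this assay compound 1 gives only a limit, > 100000 nM, so no number is known for it. Compound 2 `Cc1cc(C)cc(Cn2c(=O)cc(N=[N+]=[N-])n(Cc3ccccn3)c2=O)c1` likewise gives only a limit in this assay, > 100000 nM. Both measured values therefore sit at the limit of > 100000 nM in this assay, at which 2 of the 2 values shown sit, and no difference between them can be read; nothing about a direction or size of change is on record for this pair.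

Compound 3 `Cc1cc(C)cc(Cn2c(=O)cc(NC3CCCCC3)n(Cc3ccccc3)c2=O)c1` is the next member, so far without a measurement. Relative to compound 1 the change is cyclohexyl in place of cyclopropyl on a nitrogen on an aromatic ring, in words: cyclohexyl in place of cyclopropyl on a nitrogen on an aromatic ring. Among the measured compounds shown here, no measured step bears on this change, so the expectation rests on the position of compound 1 alone. With compound 1 at the limit, the expected step from compound 1 to compound 3 is none beyond the scatter, a number no higher from compound 1 to compound 3 (the limit leaves the size open), and the most likely outcome is that compound 3 is again reported only as a limit. The estimate for compound 3 in this assay is 100000 nM, with a range from 30000 nM to 300000 nM.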

Compound 3, half-maximal cytotoxic concentration: 74000 nM
The estimate for compound 3 lay 1.4-fold (0.13 log units) above the measured number; the measured number falls inside the stated range.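

In this assay compound 3 is the one member of the series shown with a number rather than a limit, so a group at this position can bring the read-out inside the range the assay can quantify. Cyclohexyl in place of cyclopropyl on a nitrogen on an aromatic ring gives an at least 1.3-fold lower number from compound 1 to compound 3 (0.13 log units; that floor lies within the scatter), so the change from 3 to 6 heavy atoms in the ring establishes no real difference in this read-out. The value of compound 1 is a limit, which leaves the step as a floor only, and that limit still holds most of the values shown: the limit of > 100000 nM in this assay, at which 2 of the 3 values shown sit.

From the compounds shown here alone, it remains open whether the read-out follows ring size on this nitrogen or belongs to cyclohexyl alone; cyclopentyl, or an open chain such as hexyl, in the same place would separate the two. Also open, going by these compounds, is how the read-out responds to an amine or a carboxylic acid at the end of such a chain.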